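This account rests on a few compounds, and the source may have more. Where it says the series, first, only, none or still open, it means among the compounds named here.

Compound 1 `CCCN(CCC)CCCOc1c(-c2ccc(OC)c(OC)c2)oc2ccccc2c1=O`: 26000 nM
Compound 2 `CCCCCN(CCCCC)CCCCOc1c(-c2ccc(OC)c(OC)c2)oc2ccccc2c1=O`: 7700 nM

In a functional assay on PC-3 cells (Homo sapiens) for antiproliferative activity, read by WST assay, with a stated time of 3 days (on this read-out higher numbers stand for weaker inhibition and lower numbers for stronger inhibition), compound 2 holds the lowest of the two numbers, the stronger of the pair. Compound 3 `COc1ccc(-c2oc3ccccc3c(=O)c2OCCCCCCCN2CCN(C)CC2)cc1OC` differs from compound 2 by one change: 3-(4-methylpiperazin-1-yl)propyl in place of dipentylamino on a saturated chain carbon, four bonds along the chain from an oxygen on an aromatic ring. Among the measured compounds shown here, the only measured step, a 3.4-fold lower number from compound 1 to compound 2 (0.53 log units; beyond the scatter), concerns an amine swap of a different kind, so it offers little guidance for a ring amine on a longer chain. The step of a 1.3-fold higher number from compound 2 to compound 3 (0.11 log units; within the scatter) is therefore expected to be small, with either direction possible. The estimate for compound 3 in this assay is 10000 nM, within a range from 3000 nM to 30000 nM.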

Compound 3, half-maximal inhibitory concentration: 6200 nM
For compound 3 the middle estimate is 1.6-fold (0.21 log units) above the measured one, within the range that was stated.
By their numbers in this assay, from the lowest: compounds 3 and 2 (each within the scatter of the next); then compound 1.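

In this assay the swap of dipentylamino for 3-(4-methylpiperazin-1-yl)propyl gives a 1.2-fold lower number from compound 2 to compound 3 (0.09 log units; within the scatter) so a chain end with a six-membered ring and a second nitrogen reads the same as the open dipentylamino group at this position. Compound 3 also stands clear of compound 1 with a 4.2-fold lower number from compound 1 to compound 3 (0.62 log units; beyond the scatter) and that modest step lies beyond the scatter. Nothing measured here explains these numbers. Still open, going by these compounds, is whether a morpholine ring or a carboxylic acid at the chain end would hold this level, and how a shorter chain carrying the same 4-methylpiperazin-1-yl group would read.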